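The source may hold more compounds than are shown below. What is called first, only, known or untested is meant among the compounds shown, and "the series" means these compounds.

Compound 1 `O=C1C=C(NCc2ccccc2)C(=O)c2c1nc1n2[C@H]2OC[C@@H](O)[C@H]2OC1`, compound 2 `O=C1C=C(Nc2ccccc2)C(=O)c2c1nc1n2[C@H]2OC[C@@H](O)[C@H]2OC1` and compound 3 `O=C1C=C(NC2CCCCC2)C(=O)c2c1nc1n2[C@H]2OC[C@@H](O)[C@H]2OC1` have been measured in a functional assay on MCF7 cells (Homo sapiens) for inhibition, read by sulforhodamine B assay; on this read-out lower numbers stand for stronger inhibition and higher numbers for weaker inhibition. Compound 1 gives only a limit, > 8000 nM. Compound 2 likewise gives only a limit, > 4000 nM. Compound 3 too gives only a limit, > 8000 nM.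

Compound 3 thus stands at one of the two limits shown, without a number of its own. Compound 4 `O=C1C=C(N2CCCCC2)C(=O)c2c1nc1n2[C@H]2OC[C@@H](O)[C@H]2OC1` differs from it by piperidin-1-yl in place of cyclohexylamino on a double-bonded ring carbon. The measured steps a step that the two limits leave unreadable from compound 1 to compound 2, a step that the two limits leave unreadable from compound 1 to compound 3 and a step that the two limits leave unreadable from compound 2 to compound 3 cannot be read in size: every value shown is a limit, as the limit of > 4000 nM in this assay, at which 1 of the 3 values shown sits, and the limit of > 8000 nM in this assay, at which 2 of the 3 values shown sit, make plain. None of them touches the exchange of cyclohexylamino for piperidin-1-yl. No step beyond the scatter can therefore be expected in this assay, in either direction. Compound 4 is expected to give 10000 nM, in a range from 3000 nM to 30000 nM, most probably again only a limit. The expected step from compound 3 is estimated as a step that the limit leaves unreadable from compound 3 to compound 4.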

Compound 4, half-maximal inhibitory concentration: > 8000 nM
Compound 4 ended at the assay's limit; the forecaster's own chance of this, stated with the estimate: 80%; the middle value does not contradict the limit.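

Compound 4, like compound 1, compound 2 and compound 3, gives only a limit in this assay, so no new step can be read. The compounds shown leave open whether any amine group here differs from another in inhibition.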